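The source may hold more compounds than are shown below. What is called first, only, known or untested is meant among the compounds shown, and "the series" means these compounds.

Compound 1 `CCN(CC)CCCOc1cc2ncnc(Nc3nc4ccc(C(=O)Nc5c(C)cccc5C)cc4s3)c2cc1OC` was tested in a functional assay on DLD-1 cells (Homo sapiens) for cytotoxicity, read by WST assay, with a stated time of 72 h; a lower number here means a stronger inhibitor, a higher number a weaker inhibitor. In this assay compound 1 gives only a limit, > 100000 nM. Within the data shown here, compound 2 `COc1cc2c(Nc3nc4ccc(C(=O)Nc5c(C)cccc5C)cc4s3)ncnc2cc1OCCCN1CCCCC1C` forms the one measured step with it. In this assay compound 2 also gives only a limit, > 100000 nM. That step, a step that the two limits leave unreadable from compound 1 to compound 2, stays unreadable because of the limit of > 100000 nM in this assay, at which 2 of the 2 values shown sit. Compound 3 `CCN(CC)CCCOc1cc2ncnc(Nc3nc4ccc(C(=O)Nc5c(C)cc(C)cc5C)cc4s3)c2cc1OC` differs from compound 1 by methyl in place of hydrogen on an aromatic carbon, turning 2,6-dimethylphenyl into 2,4,6-trimethylphenyl. Among the measured compounds shown here, no measured step covers such a change, so nothing beyond the scatter is expected. The expected step is a number no higher from compound 1 to compound 3 (the limit leaves the size open). Compound 3 is expected to give 100000 nM, between 30000 nM and 300000 nM, most likely again as a limit.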

Compound 3, half-maximal inhibitory concentration: 6800 nM
Compound 3: middle estimate off by 15-fold (1.17 log units), on the high side; measured number below the stated range.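

In this assay, among these compounds, one added methyl on the 2,6-dimethylphenyl ring, at the carbon para to a large group, produces the only readable change here: an at least 14-fold lower number from compound 1 to compound 3 (1.16 log units; beyond the scatter). This position is therefore sensitive, and a single carbon there is enough to bring the number out of the limit. The earlier step could not show this, because it cannot be read: the limit of > 100000 nM in this assay, at which 2 of the 3 values shown sit.

From the compounds shown here alone, it remains open whether chlorine or methoxy at this carbon would act as methyl does. Also open, going by these compounds, is whether this methyl would give a similar step on compound 2, with its 2-methylpiperidin-1-yl group.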